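Moving the chlorine on the amide-linked phenyl: cytotoxicity outlook

The source may report more compounds than this note shows. Statements on the series, on what has been measured and on what is new or still open speak of the compounds shown alone.

Compound 1 `CC1=C(C(=O)Nc2ccccc2Cl)C(c2cccs2)NC(=O)N1`: in an ADME assay on Vero cells (Chlorocebus sabaeus) for cytotoxicity, read by XTT assay, with a stated time of 72 h (on this read-out lower numbers stand for higher toxicity in this test and higher numbers for lower toxicity in this test), compound 1 gives > 100000 nM, which is a limit of the assay rather than a number.
Compound 2 `CC1=C(C(=O)Nc2cccc(Cl)c2)C(c2cccs2)NC(=O)N1`: in this assay compound 2 gives > 100000 nM, again a limit.
Compound 3 `CC1=C(C(=O)Nc2ccccc2Cl)C(c2cnc(CS)n2Nc2ccccc2)NC(=O)N1`: in this assay compound 3 gives > 100000 nM, likewise a limit.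

The change from compound 1 to compound 2 is 3-chlorophenyl in place of 2-chlorophenyl on an amide-type nitrogen, and in this assay it gave a step that the two limits leave unreadable from compound 1 to compound 2. Compound 4 `CC1=C(C(=O)Nc2cccc(Cl)c2)C(c2cnc(CS)n2Nc2ccccc2)NC(=O)N1` carries the same change relative to compound 3, (3-chlorophenyl in place of 2-chlorophenyl on an amide-type nitrogen), at a place described in identical words. How the core of compound 1 differs from that of compound 3 is not broken down here. Because (the limit of > 100000 nM in this assay, at which 3 of the 3 values shown sit), compound 4 is expected to sit at the limit too, with an expected step that the limit leaves unreadable from compound 3 to compound 4. The estimate for compound 4 in this assay is 150000 nM, between 60000 nM and 400000 nM.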

Compound 4, half-maximal cytotoxic concentration: 98600 nM
Compound 4: middle estimate off by 1.5-fold (0.18 log units), on the high side; the range from low to high includes it.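

In this assay, moving to 3-chlorophenyl on the core of compound 3 gives an at least 1.0-fold lower number from compound 3 to compound 4 (0.00 log units; that floor lies within the scatter), so no real shift is shown. Among the compounds shown here, the same change on the core of compound 1 cannot be read, which means that there is no measured step on that core to set beside this one. The true size of the new step and any agreement between the two cores therefore stay unknown, because so few readings are actual numbers: the limit of > 100000 nM in this assay, at which 3 of the 4 values shown sit.

Also open, on these data alone, is what an amine or a carboxylic acid in place of the chlorine would do in this assay. Whether either core would tolerate such a group equally is equally unsettled.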